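This account rests on a few compounds, and the source may have more. Where it says the series, first, only, none or still open, it means among the compounds named here.

Values in a functional assay on the whole organism (brain) with Mus musculus as the target; on this read-out lower numbers stand for an effect already at smaller amounts and higher numbers for an effect only at larger amounts of compound:
compound 1 `CC(=O)c1ccc(OCCc2c[nH]cn2)cc1`: 3.2 mg/kg
compound 2 `Clc1ccc(OCCc2c[nH]cn2)cc1`: 0.78 mg/kg
compound 3 `Fc1c(F)c(F)c(OCCc2c[nH]cn2)c(F)c1F`: 10 mg/kg

Compound 2 stands lowest of the three, and both other numbers lie higher beyond the scatter. The next compound is compound 4 `CCc1ccc(OCCc2c[nH]cn2)cc1`, with ethyl in place of chloro on an aromatic carbon. For the measured compounds named here, the only measured step bearing on this is a 4.1-fold lower number from compound 1 to compound 2 (0.61 log units; beyond the scatter), a modest step with chloro in place of acetyl. Going by the values given here, no measured compound carries ethyl, so this is indirect guidance. With compound 2 at 0.78 mg/kg as the low end of the series, a small move towards a higher number is expected in this assay. The expected step is a 1.7-fold higher number from compound 2 to compound 4 (0.22 log units; within the scatter). For compound 4 the estimated value is 1.3 mg/kg, with an expected range of 0.45 mg/kg to 3.8 mg/kg.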

Compound 4, dose for half-maximal effect: > 10 mg/kg
Compound 4 was reported as a limit (the forecaster's own chance of this, stated with the estimate: 3%); middle value at least 7.6-fold (0.88 log units) from the limit.
By their numbers in this assay, from the lowest: compound 2; then compound 1; then compound 3.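

At this position on the aromatic ring, ethyl does not stand in for chloro in this assay, with an at least 12-fold higher number from compound 2 to compound 4 (1.10 log units; beyond the scatter). Ethyl also falls behind acetyl, with an at least 3.1-fold higher number from compound 1 to compound 4 (0.49 log units; beyond the scatter), so chloro, acetyl and ethyl now rank in that order from the lowest number at this one place. The figure for compound 4 is a limit of the assay, not a number: the limit of > 10 mg/kg in this assay, at which 1 of the 4 values shown sits.

As far as these compounds go, how far ethyl really lies from chloro and acetyl remains open. So does the reading of methyl, methoxy, an amine or a carboxylic acid at this position, and why ethyl and chloro differ.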